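The source may report more compounds than this note shows. Statements on the series, on what has been measured and on what is new or still open speak of the compounds shown alone.

Compound 1 `Cc1cccc(-c2cc(-c3ccc(Cl)o3)cc(-c3ccsc3)n2)c1` gives 7.5% in an assay on isolated protein for inhibition of DNA topoisomerase 1 (Homo sapiens), tested at 100 uM; on this read-out higher numbers stand for a stronger effect at the one concentration tested and lower numbers for a weaker effect.
Compound 2 `Clc1ccc(-c2cc(-c3ccoc3)cc(-c3cccs3)n2)cc1` gives 0% in this assay.
Compound 3 `Clc1ccc(-c2cc(-c3ccoc3)cc(-c3ccsc3)n2)cc1` gives 0% in this assay.

Compound 1 has the highest of the three numbers, yet its gaps to compound 2 and to compound 3 are each within the scatter, so the three compounds cannot be told apart on these data. For the measured compounds named here, the only step measured between two compounds that differ in one place is no change at the digits printed from compound 2 to compound 3 (within the scatter), a swap of one five-membered ring for another on the shared core.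

Compound 4 `Clc1ccc(-c2cc(-c3cccnc3)nc(-c3ccsc3)c2)o1` has not yet been measured. It differs from compound 1 in one place: pyridin-3-yl in place of 3-methylphenyl on an aromatic carbon. Going by the values given here, no measured step covers a change of this kind; the one step that exists, from compound 2 to compound 3, is a different swap and showed nothing beyond the scatter. With all three measured numbers sitting low and close together, compound 4 is expected to stay in the same region, and the step of a number 2.5 percentage points lower from compound 1 to compound 4 (within the scatter) is estimated to be no more than scatter. Compound 4 is therefore estimated at 5%, with a range from 0% to 20%.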

Compound 4, a percentage reported as inhibition, at one concentration (the size of the read-out at that concentration, not a potency): 0%
Beside the measured number, compound 4's estimate is 5 percentage points above it, and the stated range covers the measured number.
By their numbers in this assay, from the lowest: compounds 2, 3, 4 and 1 (each within the scatter of the next).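

The step from 3-methylphenyl to pyridin-3-yl, on the aromatic carbon next to the ring nitrogen, reads as a number 7.5 percentage points lower from compound 1 to compound 4 (within the scatter) in this assay. It is the first step shown at this position, where the earlier step concerned only the thiophene attachment, and it shows that exchanging this carbon-only ring for a ring with one hetero atom, which adds a hydrogen-bond acceptor, does not move the number beyond the scatter. Nothing available here bears on why the number stays within the scatter.

What the compounds shown leave open is whether any group at this position can lift the read-out beyond the scatter at the one concentration tested. An amine or a carboxylic acid on this ring, or a longer chain in its place, could still behave differently.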